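The source may hold more compounds than are shown below. What is called first, only, known or untested is meant among the compounds shown, and "the series" means these compounds.

Of the compounds shown here, three sharing one core have been tested in an assay on HEK293 cells for antagonist activity at P2X purinoceptor 7 (Homo sapiens), read by fluorescence, with a stated time of 2 h; on this read-out lower numbers stand for stronger inhibition and higher numbers for weaker inhibition. Compound 1 `Nc1cccc(S(=O)(=O)Oc2ccc(-c3cncn3C3CCN(C(=O)c4ccc(Cl)c(C(F)(F)F)c4)CC3)cc2)c1` gives 565 nM. Within the data shown here, compound 2 `O=C(c1ccc(Cl)c(C(F)(F)F)c1)N1CCC(n2cncc2-c2ccc(OS(=O)(=O)c3cccc([N+](=O)[O-])c3)cc2)CC1` gives 249 nM, and the one single-point step recorded so far, a 2.3-fold lower number from compound 1 to compound 2 (0.36 log units; beyond the scatter), was a modest one. Compound 3 `COc1ccc(C(=O)N2CCC(n3cncc3-c3ccc(OS(=O)(=O)c4cccc5cnccc45)cc3)CC2)cc1` gives 77 nM, the lowest of the three numbers: compound 2 sits above it by a margin beyond the scatter, and compound 1 higher still.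

Compound 4 `CCN(CC)c1ccc(C(=O)N2CCC(n3cncc3-c3ccc(OS(=O)(=O)c4cccc5cnccc45)cc3)CC2)cc1` has not yet been measured. It differs from compound 3 in one place: diethylamino in place of methoxy on an aromatic carbon. Among the measured compounds shown here, the only measured step alters a group elsewhere on the core, so no measured step speaks directly to this change. With nothing pointing in either direction, compound 4 is expected to stay close to compound 3, and the estimated step of a 1.0-fold higher number from compound 3 to compound 4 (0.02 log units; within the scatter) is expected to lie within the usual scatter. Compound 4 is therefore estimated at 80 nM, with a range from 30 nM to 220 nM.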

Compound 4, half-maximal inhibitory concentration: 1440 nM
Compound 4: middle estimate off by 18-fold (1.26 log units), on the low side, and the stated range ends below it.
By their numbers in this assay, from the lowest: compound 3; then compound 2; then compound 1; then compound 4.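

In this assay, replacing methoxy with diethylamino on the aromatic carbon para to a large group gives a 19-fold higher number from compound 3 to compound 4 (1.27 log units; beyond the scatter), a large step. Among these compounds, the only earlier step, a modest one, concerned a different place on the core, so this is the first measured sign that the substituent at this position can strongly change the read-out. The change leaves the counts of hydrogen-bond donors and acceptors the same, while the group grows from 2 heavy atoms to 5, but no available measurement shows what causes the rise.

From the compounds shown here alone, with only methoxy and diethylamino compared here, it remains open whether the rise follows from the nitrogen, the ethyl chains or the whole group. Dimethylamino, ethoxy or a plain hydrogen at this position would help separate these possibilities.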